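The source may report more compounds than this note shows. Statements on the series, on what has been measured and on what is new or still open speak of the compounds shown alone.

All three measured compounds were tested in a functional assay on SK-BR-3 cells (Homo sapiens) for inhibition, read by MTT assay, with a stated time of 2 days, tested at 10 uM (on this read-out lower numbers stand for less inhibition of growth and higher numbers for more inhibition of growth at the one concentration tested), and their numbers are:

compound 1, `CNC(=O)c1cc(Oc2ccc3nc(NC(=O)Nc4ccc(Cl)cc4Cl)sc3c2)ccn1`, gives 22.3%;
compound 2, `CNC(=O)c1cc(Oc2ccc3nc(NC(=O)c4ccc(Cl)cc4)sc3c2)ccn1`, gives 18.9%;
compound 3, `CNC(=O)c1cc(Oc2ccc3nc(NC(=O)c4cc(Cl)cc(Cl)c4)sc3c2)ccn1`, gives 9.62%.

Compound 2 sits in the middle of these three numbers, but neither neighbour is separated from it by more than the usual scatter: the step of a number 3.4 percentage points lower from compound 1 to compound 2 (within the scatter) and the step of a number 9.3 percentage points lower from compound 2 to compound 3 (within the scatter) are both within it, so no ranking among the three can be read from the data.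

Compound 4, `CNC(=O)c1cc(Oc2ccc3nc(NC(=O)Nc4ccc(Cl)cc4)sc3c2)ccn1`, is compound 2 with one change: (4-chlorophenyl)amino in place of 4-chlorophenyl on a carbonyl carbon. Put another way, a (4-chlorophenyl)carbonyl becomes a (4-chlorophenyl)carbamoyl. Going by the values given here, the one measured step that bears on this is the step from compound 1 to compound 2, where a (2,4-dichlorophenyl)amino was replaced by a 4-chlorophenyl on the same carbonyl carbon: a number 3.4 percentage points lower from compound 1 to compound 2 (within the scatter). Among the compounds with values here, compound 4 reverses that kind of exchange while keeping the single chlorine of compound 2, so the expected step is small, a number 3.1 percentage points higher from compound 2 to compound 4 (within the scatter), without a clear direction beyond the scatter. Compound 4 is therefore estimated at 22%, in a range from 10% to 35%.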

Compound 4, percent growth inhibition at one concentration: 50.8%
Compound 4: middle estimate off by 28.8 percentage points, on the low side; measured number outside the range, above it.
By their numbers in this assay, from the lowest: compounds 3, 2 and 1 (each within the scatter of the next, the first and the last beyond it); then compound 4.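

In this assay, going by these compounds alone, (4-chlorophenyl)amino in place of 4-chlorophenyl on the carbonyl carbon brings a large rise (a number 31.9 percentage points higher from compound 2 to compound 4 (beyond the scatter)), something the earlier compounds did not reveal, as their one comparable step lay within the scatter. The rise also depends on the chlorines of the phenyl ring: hydrogen in place of chloro on an aromatic carbon separates two compounds that both carry the amino link (a number 28.5 percentage points higher from compound 1 to compound 4 (beyond the scatter)), while the widest step shown also changes the ring's chlorines (a number 41.2 percentage points higher from compound 3 to compound 4 (beyond the scatter)). Nothing available explains why this one change matters so much.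

Still open, from the compounds shown here alone, is whether a fluoro, a methoxy or a plain hydrogen in place of the remaining chloro would hold this level. A (3,5-dichlorophenyl)amino or a cyclohexylamino on the same carbonyl carbon also remains an open case.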